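The compounds below may be only part of what the source reports. "The series", "measured", "known", "first", "only" and "open" are said of these compounds alone.

Measured compounds:
compound 1, `CCCNc1nc(NCc2ccc(NC(=O)c3ccc(F)cc3)cc2)c2ccccc2n1`, 2000 nM
compound 2, `CN1CCN(c2nc(NCc3ccc(NC(=O)c4ccc(F)cc4)cc3)c3ccccc3n2)CC1`, 2500 nM
compound 3, `CN(C)CCCNc1nc(NCc2ccc(NC(=O)c3ccc(F)cc3)cc2)c2ccccc2n1`, 14000 nM

All three were tested in a functional assay on SW480 cells (Homo sapiens) for inhibition, read by luminescence and resazurin assay, with a stated time of 3 days; on this read-out higher numbers stand for weaker inhibition and lower numbers for stronger inhibition. Compound 1 gives the smallest of the three numbers; the gap a 1.3-fold higher number from compound 1 to compound 2 (0.10 log units; within the scatter) is within the scatter, while the gap a 7.0-fold higher number from compound 1 to compound 3 (0.85 log units; beyond the scatter) lies beyond it. The step of a 5.6-fold higher number from compound 2 to compound 3 (0.75 log units; beyond the scatter) points the same way. Every measured step alters the group attached to the shared core; the ((4-fluorophenyl)carbonyl)amino end is kept unchanged throughout.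

Compound 4, `CCCNc1nc(NCc2ccc(C(=O)Nc3ccc(F)cc3)cc2)c2ccccc2n1`, differs from compound 1 at exactly that untouched end: (4-fluorophenyl)carbamoyl in place of ((4-fluorophenyl)carbonyl)amino on an aromatic carbon. Going by the values given here, no measured step bears on this change, so the three steps above give no guide to its direction or size. With the same atoms rearranged, the working expectation for compound 4 in this assay is a number near that of compound 1, with a wide range to allow for a shift either way. The expected step is a 1.5-fold higher number from compound 1 to compound 4 (0.18 log units; within the scatter). Compound 4 is therefore estimated at 3000 nM, between 800 nM and 12000 nM.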

Compound 4, half-maximal inhibitory concentration: 1600 nM
Beside the measured number, compound 4's estimate is 1.9-fold (0.27 log units) above it; measured number inside the range.
By their numbers in this assay, from the lowest: compounds 4, 1 and 2 (each within the scatter of the next); then compound 3.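

In this assay, (4-fluorophenyl)carbamoyl in place of ((4-fluorophenyl)carbonyl)amino on an aromatic carbon, para to a large group, gives a 1.3-fold lower number from compound 1 to compound 4 (0.10 log units; within the scatter), so compound 1 and compound 4 cannot be told apart on this read-out. Going by these compounds alone, this is the first reading at this end of the molecule, since every earlier step altered the group attached to the shared core, and it shows that the direction of the amide link, with the same atoms joined differently, makes no difference beyond the scatter when propylamino is the group on the core. No measurement at hand explains why the two arrangements read alike.

Still open is whether the same holds with 4-methylpiperazin-1-yl or (3-(dimethylamino)propyl)amino on the core, since the carbamoyl arrangement is shown only with propylamino. Also open, on these data alone, is how this end responds to changes that do more than rearrange its atoms, such as a sulfonamide or a urea as the link, or a chlorine or a methoxy group in place of the fluorine on the aromatic ring.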